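This account rests on a few compounds, and the source may have more. Where it says the series, first, only, none or still open, it means among the compounds named here.

Measured compounds:
Compound 1 `COc1ccccc1/C=C/c1nc2ccccc2c(=O)[nH]1` in a functional assay on SK-N-MC cells (Homo sapiens) for cytotoxicity, read by MTT assay, with a stated time of 72 h (on this read-out higher numbers stand for weaker inhibition and lower numbers for stronger inhibition), gives 2880 nM.
Compound 2 `O=c1[nH]c(/C=C/c2ccccc2Br)nc2ccccc12` gives only a limit in this assay, namely > 6250 nM.
Compound 3 `COc1cccc(/C=C/c2nc3ccccc3c(=O)[nH]2)c1` gives 5130 nM in this assay.

Among the two numbers shown, compound 3 carries the higher one; the nearest is compound 1, whose number differs from it by a margin that stays within the scatter of repeated measurements. Compound 4 `O=c1[nH]c(/C=C/c2cccc(Cl)c2)nc2ccccc12` has not yet been tested in this assay. The change from compound 3 to compound 4 is chloro in place of methoxy on an aromatic carbon. Among the measured compounds shown here, the single measured step that resembles it is an at least 2.1-fold higher number from compound 1 to compound 2 (0.33 log units; beyond the scatter), in which bromo replaced methoxy; that step ran up to the limit of > 6250 nM in this assay, at which 1 of the 3 values shown sits. By analogy, a shift in the same direction, of modest size, is expected from compound 3 to compound 4, amounting to a 1.8-fold higher number from compound 3 to compound 4 (0.24 log units; within the scatter). Compound 4 is therefore estimated to give about 9000 nM, within a range from 4000 nM to 20000 nM, with a fair chance that the assay reports only a limit rather than a number.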

Compound 4, half-maximal inhibitory concentration: > 6250 nM
Compound 4 was reported as a limit; the forecaster's own chance of this, stated with the estimate: 55%; the middle value does not contradict the limit.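

In this assay, replacing methoxy with chloro meta to a large group gives an at least 1.2-fold higher number from compound 3 to compound 4 (0.08 log units; that floor lies within the scatter). This floor does not clear the scatter, unlike that of the bromo-for-methoxy change, an at least 2.1-fold higher number from compound 1 to compound 2 (0.33 log units; beyond the scatter), so the true size of the new step cannot be read. Among the compounds shown, both methoxy compounds now give numbers and both halogen compounds give only a limit, with no compound going against this: the limit of > 6250 nM in this assay, at which 2 of the 4 values shown sit.

The compounds shown leave open whether another group in this place, such as an amine, a hydroxyl or a carboxylic acid, would give a number clearly different from that of compound 3. Chloro and bromo also cannot be ranked against each other, as compound 2 and compound 4 differ in more than one place and both report limits.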